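A few compounds are considered here, and "the series" means these few. Any claim that something is new, unique, unknown or untested is made for them only; others in the source may bear on it.

Of the compounds shown here, three of one shared family have been measured so far, all differing only in the group that sits on an amide-type nitrogen. Compound 1 `O=C(NCc1ccccc1)c1cc(Oc2ccc(/C=C/c3ccccn3)cc2)ccn1` gives 27900 nM in a functional assay on HepG2 cells (Homo sapiens) for antiproliferative activity, read by CCK-8 assay, with a stated time of 48 h; a lower number here means a stronger inhibitor, a higher number a weaker inhibitor. Compound 2 `O=C(NCc1ccc(F)cc1)c1cc(Oc2ccc(/C=C/c3ccccn3)cc2)ccn1` gives 45100 nM in this assay, and compound 3 `O=C(NC1CC1)c1cc(Oc2ccc(/C=C/c3ccccn3)cc2)ccn1` gives 31000 nM in this assay. Compound 3 stands second highest of these three numbers: its nearest neighbour is compound 1, with a 1.1-fold higher number from compound 1 to compound 3 (0.05 log units; within the scatter), and its furthest is compound 2, with a 1.5-fold lower number from compound 2 to compound 3 (0.16 log units; within the scatter). Within the data shown here, both steps, like a 1.6-fold higher number from compound 1 to compound 2 (0.21 log units; within the scatter), lie within the scatter, so no compound here can be called stronger or weaker than another.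

Compound 4 `O=C(NC1CCCCC1)c1cc(Oc2ccc(/C=C/c3ccccn3)cc2)ccn1` has not yet been measured. The change from compound 3 to compound 4 is cyclohexyl in place of cyclopropyl on an amide-type nitrogen. Among the measured compounds shown here, the steps that bear on it are those that also alter the group on the amide-type nitrogen, namely a 1.1-fold higher number from compound 1 to compound 3 (0.05 log units; within the scatter) and a 1.5-fold lower number from compound 2 to compound 3 (0.16 log units; within the scatter), and neither moved the number beyond the scatter. On that ground the expected step is a 1.1-fold lower number from compound 3 to compound 4 (0.03 log units; within the scatter), that is, no change beyond the scatter. Compound 4 is therefore estimated to give 29000 nM in this assay, with a range from 12000 nM to 70000 nM.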

Compound 4, half-maximal inhibitory concentration: 20600 nM
Compound 4: middle estimate off by 1.4-fold (0.15 log units), on the high side; the range from low to high includes it.
By their numbers in this assay, from the lowest: compounds 4, 1, 3 and 2 (each within the scatter of the next, the first and the last beyond it).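

Among these compounds, on the amide-type nitrogen, cyclohexyl gives the first step in this small family that passes the scatter in this assay (a 2.2-fold lower number from compound 2 to compound 4 (0.34 log units; beyond the scatter)), a modest step with cyclohexyl in place of 4-fluorobenzyl. Against the other two groups it does not separate, as both (a 1.5-fold lower number from compound 3 to compound 4 (0.18 log units; within the scatter)) and (a 1.4-fold lower number from compound 1 to compound 4 (0.13 log units; within the scatter)) stay within the scatter, so cyclohexyl, cyclopropyl and benzyl cannot be told apart at this position, and only the pair of cyclohexyl and 4-fluorobenzyl can. No measurement is at hand that would explain this one step beyond the scatter.

The compounds shown leave open whether this position responds to groups of another kind, such as an amine or a carboxylic acid carried on the cyclohexyl ring, or a longer straight carbon chain in its place. They also leave open how much of the modest step belongs to the cyclohexyl group and how much to the fluoro on the 4-fluorobenzyl group, and whether any change to the shared core would move the number further than changes on this nitrogen have.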